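Swapping 2-Methoxyphenyl for 4-Bromophenyl in Compound 1

The compounds below may be only part of what the source reports. "The series", "measured", "known", "first", "only" and "open" are said of these compounds alone.

Of the compounds shown here, three have so far been tested in a functional assay on HL-60 cells (Homo sapiens) for antiproliferative activity, read by sulforhodamine B assay, with a stated time of 72 h; on this read-out higher numbers stand for weaker inhibition and lower numbers for stronger inhibition. Going by the values given here, compound 1 `COc1ccccc1NC(=S)N/N=C/c1ccc2ccccc2n1` gives 91700 nM in this assay, and it is the only compound here with a number rather than a limit. Compound 2 `CN(C)C(=S)N/N=C/c1cc2cccnc2s1` reaches only a limit of the assay in this assay, at > 100000 nM. Compound 3 `NC(=S)N/N=C/c1nc2ccccc2s1` likewise stops at a limit in this assay, at > 100000 nM. So the limit of > 100000 nM in this assay, at which 2 of the 3 values shown sit, frames the set, and compound 1 sits just inside it. Compound 4 `S=C(N/N=C/c1ccc2ccccc2n1)Nc1ccc(Br)cc1` has not yet been measured. It differs from compound 1 in one place: 4-bromophenyl in place of 2-methoxyphenyl on an amide-type nitrogen. Among the compounds with values here, no two measured compounds differ by a single change, so no measured step guides the expectation, and nothing here points the change in either direction. The expected step is a 1.0-fold lower number from compound 1 to compound 4 (0.01 log units; within the scatter), nothing beyond the usual scatter. Compound 4 is therefore expected to give about 90000 nM in this assay, within a range from 30000 nM to 200000 nM, with a fair chance that only a limit is reported.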

Compound 4, half-maximal inhibitory concentration: 27500 nM
Estimate against measurement, compound 4: 3.3-fold (0.51 log units) above, and the stated range ends above it.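

In this assay, the group on the amide-type nitrogen proves able to shift the result: 4-bromophenyl in place of 2-methoxyphenyl gives a 3.3-fold lower number from compound 1 to compound 4 (0.52 log units; beyond the scatter). Going by these compounds alone, this is the first measured step in the set, and it shows a modest but real gain in inhibition from one change while the core of compound 1 stays the same. Compound 2 and compound 3 each remain only a limit and offer no step to compare: the limit of > 100000 nM in this assay, at which 2 of the 4 values shown sit.

This single swap adds the bromine, removes the methoxy group and alters the substitution on the ring all at once, and the compounds shown cannot separate these changes. Also open, on these data alone, is how a carboxylic acid or a longer alkyl chain would behave on the same nitrogen, and whether any such group could bring a much larger step.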